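This account rests on a few compounds, and the source may have more. Where it says the series, first, only, none or still open, it means among the compounds named here.

Working notes on the hydrazide series.

Compound 1 `CCc1ccc(C(=O)NNc2c(Br)cccc2Br)cc1` was tested in a toxicity assay on MDCK cells (Canis lupus familiaris) for cytotoxicity, read by CCK-8 assay, with a stated time of 48 h; on this read-out higher numbers stand for lower toxicity in this test and lower numbers for higher toxicity in this test. In this assay compound 1 gives only a limit, > 100000 nM. Compound 2 `CCc1ccc(C(=O)NNc2c(Br)cc(Br)cc2Br)cc1` likewise reaches only a limit in this assay, > 100000 nM. Compound 3 `CCOc1ccc(C(=O)NNc2ccc(Br)cc2Br)cc1` also stops at a limit in this assay, > 100000 nM. The step from compound 2 to compound 1 a step that the two limits leave unreadable from compound 2 to compound 1 cannot be read, since both values are limits; the change involved is hydrogen in place of bromo on an aromatic carbon. The difference between the core of compound 3 and the core of compound 2 is not broken down here.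

Compound 4 `CCOc1ccc(C(=O)NNc2ccccc2Br)cc1` is not yet measured. It differs from compound 3 by hydrogen in place of bromo on an aromatic carbon; this is the same kind of change as that from compound 2 to compound 1, though the surroundings differ, the site in compound 2 being meta to two bromo groups and in compound 3 meta to a bromo group. For the measured compounds named here, because every value so far sits at the limit of > 100000 nM in this assay, at which 3 of the 3 values shown sit, the step from compound 3 to compound 4 in this assay is expected to be small, about a step that the limit leaves unreadable from compound 3 to compound 4, and most likely unreadable as before. For compound 4 in this assay a value of 150000 nM is estimated, with a range of 70000 nM to 400000 nM.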

Compound 4, half-maximal cytotoxic concentration: > 100000 nM
Compound 4: a limit, no number; the forecaster's own chance of this, stated with the estimate: 85%; the middle value is on the limit's open side.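

Compound 4 also gives only a limit in this assay, so the step from compound 3 to compound 4 cannot be read, as both values are limits: the limit of > 100000 nM in this assay, at which 4 of the 4 values shown sit.

The compounds shown leave open how far their true values lie beyond that limit, and whether any change to the shared core would bring a measurable value in this assay.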